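Benzodioxin Amide Tried in an Inactive Series

This account rests on a few compounds, and the source may have more. Where it says the series, first, only, none or still open, it means among the compounds named here.

Compound 1 `Cc1ccc(Nc2ncc3c(n2)N(C)C(=O)N(c2cc(NC(=O)c4cc(C(C)(C)C)cc(C(C)(C)C)c4)ccc2C)C3)cc1N` gives > 10000 nM in an ADME assay on BaF3 cells (Mus musculus) for antiproliferative activity, read by CellTiter-Glo and CCK-8 assay, with a stated time of 72 h (a higher number here means a weaker inhibitor of growth, a lower number a stronger inhibitor of growth), a limit of the assay. Compound 2 `CNc1nc(Nc2ccc(C)c([N+](=O)[O-])c2)ncc1C(=O)Nc1cc(NC(=O)c2cccc(C(F)(F)F)c2)ccc1C` gives > 10000 nM in this assay, again a limit. Compound 3 `CNc1nc(Nc2ccc(C)c(N)c2)ncc1C(=O)Nc1cc(NC(=O)c2cccc(C(F)(F)F)c2)ccc1C` gives > 10000 nM in this assay, also a limit.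

Compound 2 therefore stands only at a limit in this assay, as do all values shown (the limit of > 10000 nM in this assay, at which 3 of the 3 values shown sit). Going by the values given here, the single measured step, a step that the two limits leave unreadable from compound 2 to compound 3, lies between two limits and has no readable size. Compound 4 `CNc1nc(Nc2ccc(C)c([N+](=O)[O-])c2)ncc1C(=O)Nc1cc(NC(=O)c2ccc3c(c2)OCCO3)ccc1C` differs from compound 2 by 2,3-dihydro-1,4-benzodioxin-6-yl in place of 3-(trifluoromethyl)phenyl on a carbonyl carbon. Among the compounds with values here, no measured step bears on this change, so no direction beyond the scatter can be read for it. Compound 4 is expected to stay near the limit, a step that the limit leaves unreadable from compound 2 to compound 4 estimated as not beyond the scatter. Compound 4 is estimated at 20000 nM, ranging from 5000 nM to 100000 nM.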

Compound 4, concentration for 50% growth inhibition: > 10000 nM
Compound 4 ended at the assay's limit; the forecaster's own chance of this, stated with the estimate: 85%; the middle value is on the limit's open side.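

Going by these compounds alone, compound 2 and compound 4 both stand at a limit, so no step between them can be read: the limit of > 10000 nM in this assay, at which 4 of the 4 values shown sit. The compounds shown leave open whether any single change would give a measurable value in this assay.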